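Trifluoromethoxy in place of chloro on compound 3

A few compounds are considered here, and "the series" means these few. Any claim that something is new, unique, unknown or untested is made for them only; others in the source may bear on it.

In a functional assay (aorta) for inhibition, with Rattus norvegicus as the target (a lower number here means that less compound is needed, a higher number that more compound is needed for the effect), compound 1 `O=C1C=CC(=O)c2cnccc21` gives 374 nM as its reading. Compound 2 `O=C1C(Nc2ccc(F)cc2F)=CC(=O)c2ncccc21` gives 288 nM in the same test, and compound 3 `O=C1C(Nc2ccc(Cl)cc2)=CC(=O)c2ncccc21` gives 178 nM there. Compound 3 thus stands below compound 1 by a gap beyond the scatter, while compound 3 and compound 2 cannot be told apart.

The next compound, compound 4 `O=C1C(Nc2ccc(OC(F)(F)F)cc2)=CC(=O)c2ncccc21`, has trifluoromethoxy in place of chloro on an aromatic carbon, para to a large group: trifluoromethoxy in place of chloro on an aromatic carbon. Among the compounds with values here, no step between measured compounds that differ in one place is available, so the expectation rests on thin ground. With compound 2 at 288 nM and compound 3 at 178 nM lying within the scatter of each other, only a small shift is expected in this assay. The estimated change a 1.1-fold higher number from compound 3 to compound 4 (0.05 log units; within the scatter) is expected to stay within the scatter, with no firm direction. For compound 4 the estimated value is 200 nM, with an expected range from 90 nM to 440 nM.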

Compound 4, half-maximal effective concentration: 603 nM
For compound 4 the middle estimate is 3.0-fold (0.48 log units) below the measured one, outside the stated range (above it).
By their numbers in this assay, from the lowest: compounds 3, 2, 1 and 4 (each within the scatter of the next, the first and the last beyond it).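

In this assay, within the data shown here, the replacement of chloro by trifluoromethoxy on the aromatic carbon para to a large group gives a 3.4-fold higher number from compound 3 to compound 4 (0.53 log units; beyond the scatter) and is the first single-place step readable. This position is therefore sensitive to the group it carries, at least for this pair, and chloro is the substituent needing less compound for the effect. Nothing available bears on the reason for this shift, and one pair cannot separate the contributions of the entering oxygen and fluorine atoms.

As far as these compounds go, it remains open how methoxy, trifluoromethyl or bromo on this same carbon would read against chloro and trifluoromethoxy. Also open, from the compounds shown here alone, is whether the step holds when the same replacement is carried out on other aromatic carbons of this ring.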